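A few compounds are considered here, and "the series" means these few. Any claim that something is new, unique, unknown or untested is made for them only; others in the source may bear on it.

Three compounds have so far been characterised in an assay on isolated protein for binding affinity to Equilibrative nucleoside transporter 1 (Homo sapiens); a lower number here means a stronger inhibitor, a higher number a weaker inhibitor. Compound 1 `OC[C@H]1O[C@@H](n2cnc3c(OCc4ccccc4)ncnc32)[C@H](O)[C@@H]1O` gives 2090 nM, the lowest number of the three, and stands as the strongest inhibitor among them. Compound 2 `CCCCSc1nc(N)nc2c1ncn2[C@@H]1O[C@H](CO)[C@@H](O)[C@H]1O` gives 12000 nM in this assay, a higher number that lies beyond the scatter, and compound 3 `OC[C@H]1O[C@@H](n2cc(I)c3c(Cl)ncnc32)[C@H](O)[C@@H]1O` gives 77600 nM, higher still and likewise beyond the scatter. Compound 4 `OC[C@H]1O[C@@H](n2cnc3c(CSc4ccccc4Br)ncnc32)[C@H](O)[C@@H]1O` has not yet been measured; it differs from compound 1 by ((2-bromophenyl)sulfanyl)methyl in place of benzyloxy on an aromatic carbon. For the measured compounds named here, no pair of measured compounds differs in a single place, so nothing here shows how such an exchange shifts the number. The step of a 2.1-fold lower number from compound 1 to compound 4 (0.32 log units; beyond the scatter) is expected to be small, towards a lower number or within the scatter. Compound 4 is accordingly estimated at 1000 nM in this assay, between 200 nM and 5000 nM.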

Compound 4, half-maximal inhibitory concentration: 2400 nM
The estimate for compound 4 lay 2.4-fold (0.38 log units) below the measured number; the measured number falls inside the stated range.
By their numbers in this assay, from the lowest: compounds 1 and 4 (each within the scatter of the next); then compound 2; then compound 3.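

In this assay, placing ((2-bromophenyl)sulfanyl)methyl instead of benzyloxy on the aromatic carbon next to the ring nitrogen gives a 1.1-fold higher number from compound 1 to compound 4 (0.06 log units; within the scatter) on the shared core, the first single-place exchange available here. The number therefore does not separate the two groups, although the exchange removes oxygen and brings in sulfur and bromine. Nothing measured accounts for this match. Open, as far as these compounds go, is whether an amine or a carboxylic acid at this position would give a different number. The compounds shown also leave open what the same group gives without its bromine.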